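Compound 1 and the step to compound 4

The source may report more compounds than this note shows. Statements on the series, on what has been measured and on what is new or still open speak of the compounds shown alone.

Values measured in an ADME assay on MRC5 cells (Homo sapiens) for inhibition, with a stated time of 72 h (on this read-out higher numbers stand for an effect only at larger amounts of compound and lower numbers for an effect already at smaller amounts), are these:
Compound 1 `CCc1ccccc1C(=O)Nc1c[nH]nc1C(=O)N[C@H]1CC[C@H](OC)CC1` gives 3400 nM
Compound 2 `COc1cccc(OC)c1C(=O)Nc1c[nH]nc1C(=O)N[C@H]1CC[C@H](O)CC1` gives 34000 nM
Compound 3 `COc1cccc(OC)c1C(=O)Nc1c[nH]nc1C(=O)NN1CCOCC1` gives > 50000 nM as a limit of the assay

Compound 1 at 3400 nM holds the lower of the two true numbers, and compound 2 lies higher by more than the scatter. Compound 4 `CO[C@H]1CC[C@H](NC(=O)c2n[nH]cc2NC(=O)c2cc(Cl)cc(Cl)c2)CC1` differs from compound 1 in one place: 3,5-dichlorophenyl in place of 2-ethylphenyl on a carbonyl carbon with 3,5-dichlorophenyl in place of 2-ethylphenyl on a carbonyl carbon. Going by the values given here, the sole measured step an at least 1.4-fold higher number from compound 2 to compound 3 (0.16 log units; that floor lies within the scatter) lies on an amide-type nitrogen and so gives no size for this change. Compound 1 and compound 2 differ in two places, so their gap gives none either. With compound 1 at 3400 nM as the only anchor, the expected result in this assay is a 2.4-fold higher number from compound 1 to compound 4 (0.37 log units; beyond the scatter) as a rough estimate of uncertain direction. Compound 4 is estimated at 8000 nM with an expected range from 1500 nM to 40000 nM in this account.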

Compound 4, half-maximal effective concentration: 13000 nM
Estimate against measurement, compound 4: 1.6-fold (0.21 log units) below; the range from low to high includes it.
By their numbers in this assay, from the lowest: compound 1; then compound 4; then compound 2. At a limit, above all of these: compound 3.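

In this assay, going by these compounds alone, the step to 3,5-dichlorophenyl in place of 2-ethylphenyl on a carbonyl carbon gives a 3.8-fold higher number from compound 1 to compound 4 (0.58 log units; beyond the scatter) and is the first measured size for any change at this position. Both groups have the same count of heavy atoms and neither has hydrogen-bond donors or acceptors, yet the number still moves. Nothing measured here accounts for the step.

This single pair cannot separate the loss of the ethyl group from the gain of chlorine. On these data alone, how a plain phenyl, a 3-chlorophenyl or a phenyl carrying an amine would stand on this carbonyl carbon remains open.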